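Swapping a thiophene amide for a chlorophenyl ether

The source may report more compounds than this note shows. Statements on the series, on what has been measured and on what is new or still open speak of the compounds shown alone.

Of the compounds shown here, three from this series have been tested in a functional assay on PANC-1 cells (Homo sapiens) for inhibition, read by MTT assay, with a stated time of 24 h, tested at 10 uM; on this read-out higher numbers stand for more inhibition at the one concentration tested (going by the name of the read-out) and lower numbers for less inhibition. Compound 1 `CC(C)=CCC/C(C)=C/COc1cc(=O)n(CCCO)c2c1CC(CC=C(C)C)C(C)(C)C2` gives 18.4%, compound 2 `CC(C)=CCC1Cc2c(OCCCNC(=O)c3ccco3)cc(=O)n(CCCO)c2CC1(C)C` gives 4.3%, and compound 3 `CC(C)=CCC1Cc2c(OCCCNC(=O)c3cccs3)cc(=O)n(CCCO)c2CC1(C)C` gives 5.6%. Compound 3 thus stands second highest of the three, but its gap to compound 2 is within the scatter, and only compound 1 lies clearly above it. Compound 4 `CC(C)=CCC1Cc2c(OCCCOc3ccc(Cl)cc3)cc(=O)n(CCCO)c2CC1(C)C` differs from compound 3 as follows: 4-chlorophenoxy in place of ((thiophen-2-yl)carbonyl)amino on a saturated chain carbon, three bonds along the chain from an oxygen on an aromatic ring. The measured steps of a number 14.1 percentage points lower from compound 1 to compound 2 (beyond the scatter) and a number 12.8 percentage points lower from compound 1 to compound 3 (beyond the scatter) concern a different exchange, and a number 1.3 percentage points higher from compound 2 to compound 3 (within the scatter) shows that changing the five-membered ring on the carbonyl made no difference beyond the scatter. For the measured compounds named here, no measured step covers an amide-to-ether exchange, so only a small shift is expected in this assay; the step of a number 2.4 percentage points higher from compound 3 to compound 4 (within the scatter) is an estimate. Compound 4 is expected to give about 8%, within roughly 0% to 20%.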

Compound 4, a percentage reported as inhibition, at one concentration (the size of the read-out at that concentration, not a potency): 0%
Beside the measured number, compound 4's estimate is 8 percentage points above it, within the range that was stated.
By their numbers in this assay, from the lowest: compounds 4, 2 and 3 (each within the scatter of the next); then compound 1.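

In this assay, the 4-chlorophenoxy ether cannot be told apart from either amide at this chain position: the steps are a number 5.6 percentage points lower from compound 3 to compound 4 (within the scatter) and a number 4.3 percentage points lower from compound 2 to compound 4 (within the scatter). So replacing the amide, with its hydrogen-bond donor, by an ether with a six-membered carbon ring leaves these numbers within the scatter, while the step of a number 18.4 percentage points lower from compound 1 to compound 4 (beyond the scatter) places this ether with the amides, clearly under the open chain of compound 1. No evidence here gives a reason for either result. Open still is whether an amine or a carboxylic acid at the end of this chain would do differently. From the compounds shown here alone, a longer chain ending in the same 4-chlorophenoxy ring is equally open.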